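Chain length at the thioether: octyl toward hexadecyl

This account rests on a few compounds, and the source may have more. Where it says the series, first, only, none or still open, it means among the compounds named here.

Measured so far in a functional assay on NALM-6 cells (Homo sapiens); a higher number here means a weaker inhibitor, a lower number a stronger inhibitor:
compound 1 `CCCCCCCCSC[C@H](NC(C)=O)C(=O)CCl` gives 5600 nM
compound 2 `CCCCCCCCCCCSC[C@H](NC(C)=O)C(=O)CCl` gives 1700 nM

For the measured compounds named here, compound 1 stands at the highest of the two numbers measured; the nearest measured neighbour is compound 2, reached by a 3.3-fold lower number from compound 1 to compound 2 (0.52 log units; beyond the scatter), the only step so far.

Compound 3 `CCCCCCCCCCCCCCCCSC[C@H](NC(C)=O)C(=O)CCl` differs from compound 1 by octyl in place of hydrogen on a saturated chain carbon, eight bonds along the chain from a sulfur. This is the same kind of change as the measured step, carried much further along the same chain position. Going by the values given here, the one step that bears on it, a 3.3-fold lower number from compound 1 to compound 2 (0.52 log units; beyond the scatter), was modest and lowered the number. Among the compounds with values here, nothing measured tells whether further lengthening keeps lowering the number, levels off, or turns back, since no compound longer than compound 2 has been measured. Within the data shown here, on the single step available, a lowering beyond the scatter is expected, of a size comparable to or somewhat larger than that step. The expected step is a 7.0-fold lower number from compound 1 to compound 3 (0.85 log units; beyond the scatter). Compound 3 is therefore estimated at 800 nM in this assay, with a range from 250 nM to 3000 nM.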

Compound 3, half-maximal inhibitory concentration: 16000 nM
Compound 3: middle estimate off by 20-fold (1.30 log units), on the low side; the whole stated range lies below it.
By their numbers in this assay, from the lowest: compound 2; then compound 1; then compound 3.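

In this assay lengthening at this position does not act in one direction: the pentyl extension gives a 9.4-fold higher number from compound 2 to compound 3 (0.97 log units; beyond the scatter), which more than reverses the earlier lowering. The octyl change, read as a whole, gives a 2.9-fold higher number from compound 1 to compound 3 (0.46 log units; beyond the scatter), so the longest chain carries the highest number of the three and the lowest number sits with the chain of intermediate length in compound 2. Among these three compounds the number falls and then rises as the chain grows, and compound 3 goes against any reading that a longer chain simply gives a stronger inhibitor. Nothing at hand accounts for this turn.

Where the lowest number lies between compound 2 and compound 3 remains open, and a dodecyl or a tetradecyl chain at the thioether would narrow that down. Also open, from the compounds shown here alone, is whether the same turn would hold for a chain ending in an amine or a carboxylic acid.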